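Compound 2 to compound 4: a dinitrophenyl swap

This account rests on a few compounds, and the source may have more. Where it says the series, first, only, none or still open, it means among the compounds named here.

Values measured in an ADME assay on HEK-293T cells (Homo sapiens) for cytotoxicity, read by CCK-8 assay, with a stated time of 48 h (a lower number here means a stronger inhibitor, a higher number a weaker inhibitor), are these:
- compound 1 `Cc1cc(C)cc(NC(=O)NCCNS(=O)(=O)c2ccc(-c3ccccc3Oc3ccc([N+](=O)[O-])c([N+](=O)[O-])c3)s2)c1` gives > 50000 nM (a limit, not a number)
- compound 2 `O=C(NCCNS(=O)(=O)c1ccc(-c2ccccc2O[C@H]2CC[C@H](O)CC2)s1)Nc1ccc([N+](=O)[O-])cc1` gives 9000 nM
- compound 3 `O=[N+]([O-])c1ccc(NC(=S)NCCNS(=O)(=O)c2ccc(-c3ccccc3OCc3ccccc3)s2)cc1` gives 8900 nM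

Compound 2 stands level with compound 3, since their two values lie within the usual scatter of repeated measurements. The only other result is a limit, so it cannot be ranked exactly against them.

Compound 4 `O=C(NCCNS(=O)(=O)c1ccc(-c2ccccc2Oc2ccc([N+](=O)[O-])c([N+](=O)[O-])c2)s1)Nc1ccc([N+](=O)[O-])cc1` differs from compound 2 in one place, with 3,4-dinitrophenyl in place of 4-hydroxycyclohexyl on an oxygen on an aromatic ring. For the measured compounds named here, no measured pair shows this change alone. Compound 1 also carries 3,4-dinitrophenyl and gives the limit > 50000 nM, though it differs from compound 4 elsewhere too. That single result points to a moderate move toward a higher number, and compound 4 may also return only a limit. The expected change is a 2.2-fold higher number from compound 2 to compound 4 (0.35 log units; beyond the scatter) in this assay. For compound 4 the estimated value is 20000 nM, with an expected range from 7000 nM to 50000 nM.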

Compound 4, half-maximal inhibitory concentration: 16600 nM
The estimate for compound 4 lay 1.2-fold (0.08 log units) above the measured number; low and high end bracket the measured number.
By their numbers in this assay, from the lowest: compounds 3, 2 and 4 (each within the scatter of the next). At a limit, above all of these: compound 1.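

In this assay, putting the aromatic 3,4-dinitrophenyl on this oxygen in place of the non-aromatic 4-hydroxycyclohexyl gives a 1.8-fold higher number from compound 2 to compound 4 (0.27 log units; within the scatter), so the two groups stand level here despite their different rings and counts of heavy atoms. With 3,4-dinitrophenyl kept, the change elsewhere does register: 4-nitrophenyl in place of 3,5-dimethylphenyl on an amide-type nitrogen gives an at least 3.0-fold lower number from compound 1 to compound 4 (0.47 log units; beyond the scatter), and that step starts from a limit, so its true size is not known. Compound 1 gives a limit, not a number: the limit of > 50000 nM in this assay, at which 1 of the 4 values shown sits.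

The compounds shown leave open whether a group on this oxygen bearing an amine or a carboxylic acid would also stand level. They also leave open how 4-hydroxycyclohexyl would read with 3,5-dimethylphenyl on the amide-type nitrogen.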